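The source may hold more compounds than are shown below. What is called first, only, known or untested is meant among the compounds shown, and "the series" means these compounds.

Measured compounds in a functional assay on DU-145 cells (Homo sapiens) for antiproliferative activity, read by MTT assay, with a stated time of 24 h; on this read-out higher numbers stand for weaker inhibition and lower numbers for stronger inhibition:

compound 1, `COc1cc(/C=C/C(=O)c2cc(-c3cc(OC)c(OC)c(OC)c3)n3nc(-c4ccccc4)cc3n2)cc(OC)c1OC`: 17900 nM
compound 2, `COc1cc(-c2cc(/C=C/C(=O)c3ccc(C)c(C)c3)nc3cc(-c4ccccc4)nn23)cc(OC)c1OC`: 15400 nM
compound 3, `COc1cc(-c2cc(C(=O)/C=C/c3ccc(C)cc3)nc3cc(-c4ccccc4)nn23)cc(OC)c1OC`: 21900 nM

All three sit close together. Compound 3 has the highest of the three numbers, but its separation from compound 1 and from compound 2 is within the scatter, so no order among them can be read. The two one-place steps, a 1.2-fold higher number from compound 1 to compound 3 (0.09 log units; within the scatter) and a 1.4-fold higher number from compound 2 to compound 3 (0.15 log units; within the scatter), are both within the scatter; they concern changes on the chain and on the aryl end of the chain, not a substituent swap on an aromatic carbon.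

Compound 4, `COc1cc(-c2cc(C(=O)/C=C/c3ccc(Cl)cc3)nc3cc(-c4ccccc4)nn23)cc(OC)c1OC`, differs from compound 3 as follows: chloro in place of methyl on an aromatic carbon

Among the measured compounds shown here, no measured step touches this kind of exchange; the series so far gives no example of a halogen for a methyl on that ring. With three compounds all within the scatter of one another and no step beyond it, the working expectation is that compound 4 stays in the same region. Compound 4 is therefore estimated at 20000 nM in this assay, with a range of 9000 nM to 45000 nM. That estimate corresponds to an expected step of a 1.1-fold lower number from compound 3 to compound 4 (0.04 log units; within the scatter), i.e. none beyond the scatter.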

Compound 4, half-maximal inhibitory concentration: 19500 nM
The estimate for compound 4 lay 1.0-fold (0.01 log units) above the measured number; low and high end bracket the measured number.
By their numbers in this assay, from the lowest: compounds 2, 1, 4 and 3 (each within the scatter of the next).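

In this assay, among the compounds shown here, chloro in place of methyl on an aromatic carbon para to a large group gives a 1.1-fold lower number from compound 3 to compound 4 (0.05 log units; within the scatter) and so leaves the number within the scatter, the first reading of a halogen for a methyl on this ring. With chloro on this ring, the other exchanges also stay within the scatter: 4-chlorophenyl in place of 3,4,5-trimethoxyphenyl gives a 1.1-fold higher number from compound 1 to compound 4 (0.04 log units; within the scatter) and the change of the chain with its aryl end gives a 1.3-fold higher number from compound 2 to compound 4 (0.10 log units; within the scatter) on the same footing. No measured information bears on why this exchange behaves as it does.

The compounds shown leave open whether an amine or a carboxylic acid on that aromatic carbon would move the number beyond the scatter. They also leave open what the phenyl and 3,4,5-trimethoxyphenyl groups on the shared core contribute, as all four compounds carry both unchanged.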